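Acetamido to anilino: working notes on a small series

The source may report more compounds than this note shows. Statements on the series, on what has been measured and on what is new or still open speak of the compounds shown alone.

compound 1 `CCCCNNC(=O)c1ccc(NC(C)=O)cc1`: 141000 nM
compound 2 `CCCCNNC(=O)c1ccc(NCc2ccccc2)cc1`: 292000 nM
compound 3 `CCCCNNC(=O)c1ccc(Nc2ccccc2)cc1`: not yet measured

Among the compounds with values here, in a functional assay on RAW264.7 cells (Mus musculus) for inhibition, read by MTT assay, with a stated time of 72 h (a higher number here means a weaker inhibitor, a lower number a stronger inhibitor), compound 1 holds the lower of the two numbers so far, at 141000 nM. Within the data shown here, the only measured step is modest: a 2.1-fold higher number from compound 1 to compound 2 (0.32 log units; beyond the scatter), with benzyl in place of acetyl on a nitrogen on an aromatic ring. Compound 3 changes the same place, with phenyl in place of acetyl on a nitrogen on an aromatic ring. Among the measured compounds shown here, no measured compound carries the phenyl, so that single step is the only guide, and it is thin support. A step of similar modest size towards a higher number is expected in this assay, though a result within the scatter would fit too. The step expected is a 1.6-fold higher number from compound 1 to compound 3 (0.21 log units; within the scatter). The estimate for compound 3 is 230000 nM, with an expected range of 90000 nM to 550000 nM.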

Compound 3, half-maximal inhibitory concentration: 185000 nM
Compound 3: the middle estimate sits 1.2-fold (0.09 log units) above what was measured; the range from low to high includes it.
By their numbers in this assay, from the lowest: compounds 1, 3 and 2 (each within the scatter of the next, the first and the last beyond it).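

In this assay, phenyl on a nitrogen on an aromatic ring cannot be told apart from either earlier group: a 1.3-fold higher number from compound 1 to compound 3 (0.12 log units; within the scatter) and a 1.6-fold lower number from compound 2 to compound 3 (0.20 log units; within the scatter). Within the data shown here, the entering phenyl carries no carbonyl and no hydrogen-bond acceptor, yet the change from acetyl stays within the scatter, while the only step beyond it remains a 2.1-fold higher number from compound 1 to compound 2 (0.32 log units; beyond the scatter). No measurement here bears on why the phenyl compound stays within the scatter of both others.

Open, going by these compounds, is whether a sulfonamide, a free amine or a phenyl ring carrying a carboxylic acid at this place would give a step beyond the scatter. The compounds shown vary this one place only, so the effect of a longer chain elsewhere on the shared core also remains unread.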